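The source may report more compounds than this note shows. Statements on the series, on what has been measured and on what is new or still open speak of the compounds shown alone.

In a functional assay on the whole organism for antagonist activity, with Rattus norvegicus as the target (on this read-out lower numbers stand for an effect already at smaller amounts and higher numbers for an effect only at larger amounts of compound), three compounds have been measured so far. Compound 1 `O=C(Nc1ccc(C(=O)N2CCCN(Cc3ccccc3)c3sccc32)cc1)c1ccccc1-c1ccccc1` gives > 0.3 mg/kg, which is a limit and not a number. Compound 2 `O=C(Nc1ccc(C(=O)N2CCCN(CCN3CCCC3)c3sccc32)cc1)c1ccccc1-c1ccccc1` gives > 0.3 mg/kg, and this too is only a limit. Compound 3 `O=C(Nc1ccc(C(=O)N2CCCCc3sccc32)cc1OCCCC(=O)N1CCC(N2CCCCC2)CC1)c1ccccc1-c1ccccc1` gives a true number, 0.03 mg/kg, but it differs from the other two in more than one place, so it offers no single step to reason from. Compound 2 thus stands at the limit of > 0.3 mg/kg in this assay, at which 2 of the 3 values shown sit.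

Compound 4 `CN(C)CCN1CCCN(C(=O)c2ccc(NC(=O)c3ccccc3-c3ccccc3)cc2)c2ccsc21` keeps all of compound 2 except the end of one chain: dimethylamino in place of pyrrolidin-1-yl on a saturated chain carbon, two bonds along the chain from a nitrogen on an aromatic ring in a ring. In other words, 2-(pyrrolidin-1-yl)ethyl becomes 2-(dimethylamino)ethyl. For the measured compounds named here, the one measured step that touches this chain is a step that the two limits leave unreadable from compound 1 to compound 2. Going by the values given here, with limits at both ends, it gives no size to carry over, and no measured step shows what this exchange does. The working expectation in this assay is therefore no step beyond the usual scatter, in neither direction. The expected step is a step that the limit leaves unreadable from compound 2 to compound 4. The estimate for compound 4 is 0.5 mg/kg, with an expected range from 0.12 mg/kg to 2 mg/kg. Another result reported only as a limit would not be a surprise.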

Compound 4, dose for 50% inhibition: 0.31 mg/kg
Beside the measured number, compound 4's estimate is 1.6-fold (0.21 log units) above it; the measured number falls inside the stated range.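

In this assay, compound 1 and compound 2 are each known only as a limit and not as a number, and no new step can be read from either of them to compound 4. What the compounds shown leave open is whether dimethylamino in place of pyrrolidin-1-yl on this chain changes the dose at all, and in which direction.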